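The compounds below may be only part of what the source reports. "The series", "measured", "known", "first", "only" and "open" are said of these compounds alone.

Measured so far:

compound 1, `O=C(CCCCc1cn(Cc2ccc3oc(-c4ccccc4)cc(=O)c3c2)nn1)Nc1ccccc1`: 15600 nM
compound 2, `Cc1ccc(NC(=O)CCCCc2cn(Cc3ccc4oc(-c5ccccc5)cc(=O)c4c3)nn2)cc1`: 15600 nM
compound 3, `Cc1ccc(NC(=O)CCc2cn(Cc3ccc4oc(-c5ccc(Cl)cc5)cc(=O)c4c3)nn2)cc1`: 32900 nM

In an assay on isolated protein for inhibition of Amine oxidase [flavin-containing] B (Homo sapiens), read by fluorescence and spectrophotometry (on this read-out higher numbers stand for weaker inhibition and lower numbers for stronger inhibition), compound 2 gives 15600 nM and compound 1 gives 15600 nM. Within the data shown here, the step of no change at the digits printed from compound 2 to compound 1 (within the scatter) is the only single-place change measured so far; the change itself reads (hydrogen in place of methyl on an aromatic carbon).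

Compound 3, in this assay, gives 32900 nM, the highest number of the three. How compound 3 relates to compound 2 is not a single-place change; the difference between the two cores is not broken down here, so the two values are simply set side by side.

Compound 4, `O=C(CCc1cn(Cc2ccc3oc(-c4ccc(Cl)cc4)cc(=O)c3c2)nn1)Nc1ccccc1`, is not yet measured in this assay. It differs from compound 3 by hydrogen in place of methyl on an aromatic carbon. The place of the change is described in the same words as the change from compound 2 to compound 1, so this is the same change made on the core of compound 3.

Among the measured compounds shown here, the expectation for compound 4 rests on the one measured instance: the step of no change at the digits printed from compound 2 to compound 1 (within the scatter) showed no change within the scatter, so the step of a 1.0-fold higher number from compound 3 to compound 4 (0.00 log units; within the scatter) is expected to be of the same size, again within the scatter. Compound 4 is therefore estimated in this assay at 33000 nM, with the likely range running from 15000 nM to 75000 nM. For the measured compounds named here, with only one prior instance of the change, and that on a different core, the range is kept wide.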

Compound 4, half-maximal inhibitory concentration: 32900 nM
Estimate against measurement, compound 4: 1.0-fold (0.00 log units) above; low and high end bracket the measured number.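

In this assay, the change from 4-methylphenyl to phenyl on the core of compound 3 reads no change at the digits printed from compound 3 to compound 4 (within the scatter) and agrees with the earlier step on the core of compound 1: the same change on two cores in this assay, no change at the digits printed (within the scatter) from compound 2 to compound 1 and no change at the digits printed (within the scatter) from compound 3 to compound 4, 1.0-fold (0.00 log units) apart, within the scatter of two such steps. For these two cores, then, the methyl on this aromatic carbon can be removed with no visible effect on the read-out, and a flat step measured on one core was a sound guide to the step on the other. This shows transfer only between two cores and only for a step that stays within the scatter, so it does not establish that the change is silent on further cores, nor does agreement between two flat steps say why either is flat.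

Open, from the compounds shown here alone, is whether anything at this place other than methyl or hydrogen moves the number, for example a methoxy group, a fluorine, an amine or a carboxylic acid. Also open, going by these compounds, is what the linking chain and the chlorine each contribute on their own, since the core of compound 1 and the core of compound 4 differ in more than one place, and whether a shorter or longer chain would shift the value.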